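Lengthening the chain of compound 1 with dodecyl

The source may hold more compounds than are shown below. What is called first, only, known or untested is meant among the compounds shown, and "the series" means these compounds.

In a functional assay on SW1573 cells (Homo sapiens) for cytotoxicity, read by sulforhodamine B assay, with a stated time of 72 h (on this read-out lower numbers stand for stronger inhibition and higher numbers for weaker inhibition), compound 1 (`CCCCCCCCCC(=O)Nc1ccn([C@@H]2CO[C@H](CO)O2)c(=O)n1`) gives 40 nM. Compound 2 (`CCCCCCCCCCCCCCCC(=O)Nc1ccn([C@@H]2CO[C@H](CO)O2)c(=O)n1`) gives 20 nM, which lies within the scatter of compound 1. Compound 3 (`CCCCCCCCCCCCCCCCCC(=O)Nc1ccn([C@@H]2CO[C@H](CO)O2)c(=O)n1`) gives 125 nM, clearly higher than both.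

Compound 4 (`CCCCCCCCCCCCCCCCCCCCCC(=O)Nc1ccn([C@@H]2CO[C@H](CO)O2)c(=O)n1`) has not yet been measured. The change is dodecyl in place of hydrogen on a saturated chain carbon, nine bonds along the chain from a carbonyl carbon.

Three measured steps extend this same chain. The hexyl step, a 2.0-fold lower number from compound 1 to compound 2 (0.30 log units; within the scatter), stays within the scatter, so it shows no clear rise. The octyl step, a 3.1-fold higher number from compound 1 to compound 3 (0.49 log units; beyond the scatter), and the ethyl step, a 6.3-fold higher number from compound 2 to compound 3 (0.80 log units; beyond the scatter), are both modest rises. Dodecyl extends the chain past the octyl step, so the rise seen there bears most closely, and a somewhat larger step towards a higher number is expected. No longer chain has been measured, so the uncertainty is wide.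

The expected step is an 8.8-fold higher number from compound 1 to compound 4 (0.94 log units; beyond the scatter). Compound 4 is estimated at 350 nM, with an expected range from 100 nM to 1200 nM.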

Compound 4, half-maximal inhibitory concentration: 900 nM
Estimate against measurement, compound 4: 2.6-fold (0.41 log units) below; the range from low to high includes it.
By their numbers in this assay, from the lowest: compounds 2 and 1 (each within the scatter of the next); then compound 3; then compound 4.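

In this assay, the dodecyl change on this saturated chain carbon, nine bonds along the chain from a carbonyl carbon, gives the first large step from the shared core's shorter chain (a 23-fold higher number from compound 1 to compound 4 (1.35 log units; beyond the scatter)). The rise seen with compound 3 does not level off at that length but continues (a 7.2-fold higher number from compound 3 to compound 4 (0.86 log units; beyond the scatter)), and the gap to the hexyl-extended compound widens further (a 45-fold higher number from compound 2 to compound 4 (1.65 log units; beyond the scatter)), although the hexyl step itself, from compound 1 to compound 2, stays within the scatter and so does not join this rise. Nothing measured here accounts for the climb with the longest chains.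

As far as these compounds go, whether a still longer chain would raise the number further stays open. So does whether an amine or a carboxylic acid at the end of the chain would change this trend.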